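Shifting a Hydroxyphenyl Group on a Shared Core

The source may hold more compounds than are shown below. What is called first, only, known or untested is meant among the compounds shown, and "the series" means these compounds.

Measured compounds:
compound 1, `Oc1cccc(-c2cc(-c3ccc(F)cc3)cc(-c3ccccc3O)n2)c1`: > 50000 nM
compound 2, `Oc1cccc(-c2cc(-c3ccc(F)cc3)cc(-c3cccc(O)c3)n2)c1`: 7120 nM
compound 3, `Oc1cccc(-c2cc(-c3ccccc3C(F)(F)F)cc(-c3ccccc3O)n2)c1`: 7250 nM

Three compounds were tested in a functional assay on DU-145 cells (Homo sapiens) for inhibition; on this read-out lower numbers stand for stronger inhibition and higher numbers for weaker inhibition. Compound 1 reached only the limit of the assay, > 50000 nM, which is a limit and not a number (the limit of > 50000 nM in this assay, at which 1 of the 3 values shown sits). Compound 2 gave 7120 nM and compound 3 gave 7250 nM; these two values lie within the scatter of each other, so no order between them is claimed.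

Compound 2 differs from compound 1 by 3-hydroxyphenyl in place of 2-hydroxyphenyl on an aromatic carbon, and this brought an at least 7.0-fold lower number from compound 1 to compound 2 (0.84 log units; beyond the scatter). Compound 3 differs from compound 1 by 2-(trifluoromethyl)phenyl in place of 4-fluorophenyl on an aromatic carbon, giving an at least 6.8-fold lower number from compound 1 to compound 3 (0.83 log units; beyond the scatter).

Compound 4, `Oc1cccc(-c2cc(-c3ccccc3C(F)(F)F)cc(-c3cccc(O)c3)n2)c1`, has not yet been measured. It differs from compound 3 by 3-hydroxyphenyl in place of 2-hydroxyphenyl on an aromatic carbon, the same kind of change as that between compound 1 and compound 2, though the surroundings are not identical: in compound 1 the place is meta to a 3-hydroxyphenyl group and meta to a 4-fluorophenyl group, whereas in compound 3 it is meta to a 2-(trifluoromethyl)phenyl group and meta to a 3-hydroxyphenyl group.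

The earlier step rests on a limit for compound 1, so its true size is only bounded from below. The step from compound 3 to compound 4 is expected to be of a similar kind, a 7.3-fold lower number from compound 3 to compound 4 (0.86 log units; beyond the scatter), an expectation resting on an at least 7.0-fold lower number from compound 1 to compound 2 (0.84 log units; beyond the scatter). Compound 4 is therefore estimated at 1000 nM in this assay, within a range from 300 nM to 4000 nM.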

Compound 4, half-maximal inhibitory concentration: 2870 nM
For compound 4 the middle estimate is 2.9-fold (0.46 log units) below the measured one, within the range that was stated.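

In this assay the direction of both changes carried over to the second core: 3-hydroxyphenyl in place of 2-hydroxyphenyl gave a 2.5-fold lower number from compound 3 to compound 4 (0.40 log units; beyond the scatter), and 2-(trifluoromethyl)phenyl in place of 4-fluorophenyl gave a 2.5-fold lower number from compound 2 to compound 4 (0.39 log units; beyond the scatter). The size of the hydroxyphenyl change did not carry over, and it cannot be treated as a fixed increment in this series: the same change on two cores in this assay, an at least 7.0-fold lower number (0.84 log units; beyond the scatter) from compound 1 to compound 2 and a 2.5-fold lower number (0.40 log units; beyond the scatter) from compound 3 to compound 4, at least 2.7-fold (0.44 log units) apart, beyond the scatter of two such steps Compound 1 stands at a limit, so the true size of both earlier steps remains unknown and each gap is bounded from one side only, but the second change likewise kept its direction on these compounds without keeping its size: the same change on two cores in this assay, an at least 6.8-fold lower number (0.83 log units; beyond the scatter) from compound 1 to compound 3 and a 2.5-fold lower number (0.39 log units; beyond the scatter) from compound 2 to compound 4, at least 2.7-fold (0.44 log units) apart, beyond the scatter of two such steps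

The four compounds leave open whether the same direction would hold if the 2-(trifluoromethyl)phenyl or 4-fluorophenyl group gave way to a group carrying an amine or a carboxylic acid. They also leave open what would follow if a methoxy group took the place of the hydroxyl on either hydroxyphenyl group, so the role of that hydroxyl in these steps remains unresolved.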